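Swapping phenyl for (methylamino)methyl in compound 2

This account rests on a few compounds, and the source may have more. Where it says the series, first, only, none or still open, it means among the compounds named here.

compound 1 `C=C1CC[C@H]2[C@@](C)(CCC(=O)N[C@@]2(C)COC(=O)CCCC[C@@H]2CCSS2)[C@@H]1/C=C/C1=CCOC1=O`: 22400 nM
compound 2 `C=C1CC[C@H]2[C@@](C)(CC[C@@H](OC(=O)c3ccccc3)[C@@]2(C)NC=O)[C@@H]1/C=C/C1=CCOC1=O`: 50000 nM

In a functional assay on RAW264.7 cells (Mus musculus) for inhibition, read by Griess assay, with stated times of 3 h and 24 h (a lower number here means a stronger inhibitor, a higher number a weaker inhibitor), compound 2 stands highest of the two, at 50000 nM, and the gap down to compound 1, at 22400 nM, lies beyond the scatter. Compound 3 `C=C1CC[C@H]2[C@@](C)(CC[C@@H](OC(=O)CNC)[C@@]2(C)NC=O)[C@@H]1/C=C/C1=CCOC1=O` has not yet been measured. It keeps the rest of compound 2 and carries (methylamino)methyl in place of phenyl on a carbonyl carbon. Going by the values given here, no measured pair isolates this change, so the only guide is the range set by the two known values. A small move toward a lower number is expected. The estimated change is a 1.6-fold lower number from compound 2 to compound 3 (0.19 log units; within the scatter), which is not expected to exceed the scatter. For compound 3 the estimate is 32000 nM, with an expected range from 12000 nM to 60000 nM.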

Compound 3, half-maximal inhibitory concentration: > 50000 nM
Compound 3 was reported as a limit; the forecaster's own chance of this, stated with the estimate: 20%; middle value at least 1.5-fold (0.19 log units) away from the limit.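

In this assay compound 3 gives > 50000 nM, which is a limit of the assay and not a number. Going by these compounds alone, replacing phenyl with (methylamino)methyl on a carbonyl carbon gives a number no lower from compound 2 to compound 3 (the limit leaves the size open), the first single-place comparison in this set, and it shows no gain in inhibition from this swap. The size of this step cannot be read, and the comparison rests on a limit: the limit of > 50000 nM in this assay, at which 1 of the 3 values shown sits.

On these data alone, how far compound 3 lies from compound 2 therefore remains open, and compound 1 differs from both in more than one place, so it cannot settle the role of this position. As far as these compounds go, whether a primary amine, a carboxylic acid, a longer alkyl chain or a free hydroxyl in place of the benzoyloxy would give a lower number also remains open.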